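Notes on the aryl group: ethoxy to fluoro

This account rests on a few compounds, and the source may have more. Where it says the series, first, only, none or still open, it means among the compounds named here.

Measured in a functional assay on Jurkat cells (Homo sapiens) for antiproliferative activity, read by MTT assay, with a stated time of 72 h; on this read-out higher numbers stand for weaker inhibition and lower numbers for stronger inhibition

- Compound 1 `COc1cc(-n2ncnc2-c2ccc(C)cc2)cc(OC)c1OC` gives 300 nM
- Compound 2 `COc1ccc(-c2ncnn2-c2cc(OC)c(OC)c(OC)c2)cc1` gives 50 nM
- Compound 3 `CCOc1cccc(-c2ncnn2-c2cc(OC)c(OC)c(OC)c2)c1` gives > 10000 nM (a limit of the assay)

Compound 3 stands at a limit and has no number, as the limit of > 10000 nM in this assay, at which 1 of the 3 values shown sits, records. Compound 4 `COc1cc(-n2ncnc2-c2cccc(F)c2)cc(OC)c1OC` differs from it by fluoro in place of ethoxy on an aromatic carbon. Among the measured compounds shown here, no measured step involves either group. The nearest evidence is methoxy in place of methyl, a 6.0-fold lower number from compound 1 to compound 2 (0.78 log units; beyond the scatter), which shows that one small swap on an aromatic carbon can move the number beyond the scatter. Compound 2 at 50 nM also shows that this series can reach far lower numbers, so a drop is expected, though its size is poorly defined. The estimated at least 6.6-fold lower number from compound 3 to compound 4 (0.82 log units; beyond the scatter) points toward stronger inhibition. Compound 4 is estimated at 1500 nM within an expected range of 200 nM to 8000 nM in this assay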

Compound 4, half-maximal inhibitory concentration: > 10000 nM
Compound 4 was reported as a limit; the forecaster's own chance of this, stated with the estimate: 20%; middle value at least 6.6-fold (0.82 log units) away from the limit.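

In this assay compound 4 gives > 10000 nM, a limit and not a number, and with compound 3 also at a limit the step between them cannot be read: the limit of > 10000 nM in this assay, at which 2 of the 4 values shown sit. Against the 4-methoxyphenyl and 4-methylphenyl groups, 3-fluorophenyl gives an at least 200-fold higher number from compound 2 to compound 4 (2.30 log units; beyond the scatter) and an at least 33-fold higher number from compound 1 to compound 4 (1.52 log units; beyond the scatter). Ethoxy and fluoro, both meta to a large group, thus each leave the number at the limit, so the small fluoro gives no readable value where ethoxy gave none either.

Open, on these data alone, is whether 4-fluorophenyl would return a readable value, which would separate the place from the group. Also open, as far as these compounds go, is whether an amine on this aromatic carbon would do so.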